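Adding chloro to a phenylsulfonyl compound

The source may hold more compounds than are shown below. What is called first, only, known or untested is meant among the compounds shown, and "the series" means these compounds.

Measured in an ADME assay on HEK-293T cells (Homo sapiens) for cytotoxicity, read by MTT assay, with a stated time of 24 h; on this read-out higher numbers stand for lower toxicity in this test and lower numbers for higher toxicity in this test:
- compound 1 `FC(F)(F)c1ccc(-c2nn(-c3ccccc3)cc2-c2nc3ccccc3[nH]2)cc1` gives 167000 nM
- compound 2 `Cc1ccc(-c2nn(-c3ccccc3)cc2-c2nc3ccccc3n2S(=O)(=O)c2ccc(C(F)(F)F)cc2)cc1` gives 182000 nM
- compound 3 `O=S(=O)(c1ccccc1)n1c(-c2cn(-c3ccccc3)nc2-c2ccc(F)cc2)nc2ccccc21` gives 96300 nM

Compound 3 , at 96300 nM, lies within the usual scatter of both other compounds, so these three values cannot be told apart. Compound 4 `O=S(=O)(c1ccc(Cl)cc1)n1c(-c2cn(-c3ccccc3)nc2-c2ccc(F)cc2)nc2ccccc21` is compound 3 with chloro in place of hydrogen on an aromatic carbon, para to a large group (chloro in place of hydrogen on an aromatic carbon). For the measured compounds named here, no measured pair shows this change alone. Compound 2 , also with a substituted phenylsulfonyl group, gives 182000 nM, within the scatter of compound 3 . No step beyond the scatter is therefore expected in this assay. The expected step is a 1.2-fold higher number from compound 3 to compound 4 (0.10 log units; within the scatter). For compound 4 the estimate is 120000 nM, with an expected range from 60000 nM to 230000 nM.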

Compound 4, half-maximal cytotoxic concentration: 93100 nM
The estimate for compound 4 lay 1.3-fold (0.11 log units) above the measured number; low and high end bracket the measured number.
By their numbers in this assay, from the lowest: compounds 4, 3, 1 and 2 (each within the scatter of the next).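

In this assay, for the compounds shown here, this is the first pair that differs in one place only, and it gives a 1.0-fold lower number from compound 3 to compound 4 (0.01 log units; within the scatter). Going from phenylsulfonyl to (4-chlorophenyl)sulfonyl therefore gives two numbers that cannot be told apart, so at this position chloro and hydrogen read alike in this test. Nothing available offers an explanation for this result. From the compounds shown here alone, whether an amine or a carboxylic acid at the same place would give a step beyond the scatter stays open. So does whether chloro would read alike on a different core.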